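Two limits and an open ether

This account rests on a few compounds, and the source may have more. Where it says the series, first, only, none or still open, it means among the compounds named here.

Values in an ADME assay on CEM-SS cells (Homo sapiens) for cytotoxicity, read by XTT assay; on this read-out lower numbers stand for higher toxicity in this test and higher numbers for lower toxicity in this test:
compound 1 `CN(O)C(=O)c1cc2c(CN3CCC(O)C3)cn(Cc3ccc(F)cc3)c2cn1`: > 100000 nM
compound 2 `CN(O)C(=O)c1cc2c(CO)cn(Cc3ccc(F)cc3)c2cn1`: > 266000 nM
compound 3 `CN(O)C(=O)c1cc2c(COC3CCOCC3)cn(Cc3ccc(F)cc3)c2cn1`: not yet measured

In this assay compound 2 stands only at a limit, > 266000 nM. Compound 1 also gives only a limit, > 100000 nM. Neither figure is a number, so no toxicity has yet been measured in this series.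

Compound 3 differs from compound 2 as follows: oxan-4-yl in place of hydrogen on an oxygen on a saturated carbon. The hydroxymethyl becomes ((oxan-4-yl)oxy)methyl. Among the measured compounds shown here, the only measured step that bears on this is a step that the two limits leave unreadable from compound 1 to compound 2, which changes the same group on the shared core. For the measured compounds named here, it gives no size to carry over, so no step of definite size or direction is expected in this assay. Compound 3 may well return only a limit again.

The estimated value for compound 3 is 150000 nM, with an expected range from 40000 nM to 350000 nM. The expected step is an at least 1.7-fold lower number from compound 2 to compound 3 (0.24 log units; that floor lies within the scatter).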

Compound 3, half-maximal cytotoxic concentration: > 100000 nM
Compound 3 gave a limit, no number (the forecaster's own chance of this, stated with the estimate: 70%); the middle value lies beyond the limit too.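

In this assay compound 3 gives > 100000 nM, again a limit and not a number. With only limits in hand, no step can be read among compound 1, compound 2 and compound 3. The compounds shown leave open at what concentration, if any, these structures become toxic in this assay.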